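The source may hold more compounds than are shown below. What is called first, only, known or untested is meant among the compounds shown, and "the series" means these compounds.

Measured in a functional assay on B16-F10 cells (Mus musculus) for inhibition, read by MTT assay, with a stated time of 72 h; a lower number here means a stronger inhibitor, a higher number a weaker inhibitor:
- compound 1 `CC1(C)CC(NC(=S)Nc2ccc([N+](=O)[O-])cc2)c2cc(Br)ccc2O1`: 3000 nM
- compound 2 `CC1(C)CC(NC(=S)Nc2cccc(Cl)c2)c2cc(Br)ccc2O1`: 7000 nM

Of these two numbers, compound 2 has the higher, and compound 1 lies below it by more than the scatter. Compound 3 `CC1(C)CC(NC(=S)Nc2ccc(Cl)cc2)c2cc(Br)ccc2O1` has not yet been measured in this assay. It departs from compound 2 as follows: 4-chlorophenyl in place of 3-chlorophenyl on an amide-type nitrogen, with 4-chlorophenyl in place of 3-chlorophenyl on an amide-type nitrogen. Going by the values given here, no measured pair shows this change, so only a small move toward a lower number, within the scatter, is expected. The expected step is a 1.4-fold lower number from compound 2 to compound 3 (0.15 log units; within the scatter). For compound 3 the estimated value is 5000 nM, with an expected range of 2000 nM to 12000 nM.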

Compound 3, half-maximal inhibitory concentration: 7000 nM
Beside the measured number, compound 3's estimate is 1.4-fold (0.15 log units) below it; the measured number falls inside the stated range.
By their numbers in this assay, from the lowest: compound 1; then compounds 2 and 3 (each within the scatter of the next).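

In this assay the step of no change at the digits printed from compound 2 to compound 3 (within the scatter) shows that 4-chlorophenyl and 3-chlorophenyl on the amide-type nitrogen cannot be told apart here. Going by these compounds alone, the step of a 2.3-fold higher number from compound 1 to compound 3 (0.37 log units; beyond the scatter) gives the first one-place comparison of substituents on that aromatic carbon, with chloro in place of nitro. No evidence at hand accounts for either result. The compounds shown leave open how a methoxy group, an amine or a carboxylic acid on that aromatic carbon would read. They also leave open what a urea carbonyl in place of the thiocarbonyl would do.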